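One Added Methyl on the Strongest Compound So Far

The source may report more compounds than this note shows. Statements on the series, on what has been measured and on what is new or still open speak of the compounds shown alone.

- compound 1 `CC(C)=CCCC1=CCc2c(O)ccc(O)c2C1`: 4900 nM
- compound 2 `CC(=O)Oc1cc(C)c(OC(C)=O)c2c1CC=C(CCC=C(C)C)C2`: 14600 nM
- compound 3 `CC(C)=CCCC1=CCC2=C(C1)C(=O)C=CC2=O`: 2100 nM

All three numbers come from a functional assay on HT-29 cells (Homo sapiens) for cytotoxicity; a higher number here means a weaker inhibitor, a lower number a stronger inhibitor. Compound 3 has the lowest number of the set at 2100 nM, which makes it the strongest of the three. Its gaps to compound 1 and to compound 2 both lie beyond the usual scatter of repeated measurements, and the gap to compound 2 is the wider one.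

The next compound to be tested is compound 4 `CC(C)=CCCC1=CCC2=C(C1)C(=O)C(C)=CC2=O`, which differs from compound 3 in one place: methyl in place of hydrogen on a double-bonded ring carbon. In words, this is methyl in place of hydrogen on a double-bonded ring carbon.

For the measured compounds named here, no two measured compounds differ in just one place, so the data do not show directly what such a change does in this assay. The change is small, however, and compound 3 at 2100 nM is the natural starting point for a prediction. The expected step of no change at the digits printed from compound 3 to compound 4 (within the scatter) is no larger than the scatter, with no clear direction.

For compound 4 the estimated value is 2100 nM, with an expected range of 800 nM to 5500 nM.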

Compound 4, half-maximal inhibitory concentration: 19500 nM
Beside the measured number, compound 4's estimate is 9.3-fold (0.97 log units) below it; measured number above the stated range.
By their numbers in this assay, from the lowest: compound 3; then compound 1; then compounds 2 and 4 (each within the scatter of the next).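

This carbon is not a place where a change passes unnoticed: in this assay a methyl in place of hydrogen on the double-bonded ring carbon gives a 9.3-fold higher number from compound 3 to compound 4 (0.97 log units; beyond the scatter) and so turns compound 3 into a clearly weaker inhibitor. The step is beyond the usual scatter, although the entering group adds only 1 heavy atom and no hydrogen-bond donors or acceptors, so even a very small addition at this place can matter in this cell test. Nothing at hand explains why this methyl has such an effect.

At this carbon, the compounds shown offer only hydrogen and methyl, so one pair cannot tell whether an ethyl group, a chlorine atom or a methoxy group would also raise the number, or by how much. Going by these compounds, it also remains open whether a methyl on the other double-bonded ring carbon of the same ring would give a step of similar size, or whether this result belongs to this one place alone.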